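Cytotoxicity notes: hydroxymethyl on the chain carbon

The compounds below may be only part of what the source reports. "The series", "measured", "known", "first", "only" and "open" are said of these compounds alone.

The series shares one core; compound 1 is `NC(=O)c1cn(COC(CO)CO)c2ncnc(N)c12` and compound 2 is `N/C(=N\O)c1cn(COC(CO)CO)c2ncnc(N)c12`. Both were run in an ADME assay on HFF cells (Homo sapiens) for cytotoxicity; a higher number here means a weaker inhibitor, a lower number a stronger inhibitor. For compound 1 the result is a limit of the assay, > 320000 nM. For compound 2 the result is likewise a limit, > 100000 nM. For the measured compounds named here, the only counted step between measured compounds, a step that the two limits leave unreadable from compound 1 to compound 2, cannot be read because both ends are limits, as the limit of > 100000 nM in this assay, at which 1 of the 2 values shown sits, and the limit of > 320000 nM in this assay, at which 1 of the 2 values shown sits, record. So compound 1 stands at a limit, with no numbered value anywhere in the set to rank it against.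

Compound 3 is `NC(=O)c1cn(C(CO)OC(CO)CO)c2ncnc(N)c12`. It differs from compound 1 by hydroxymethyl in place of hydrogen on a saturated chain carbon bound to an aromatic nitrogen and an oxygen on a saturated carbon. Going by the values given here, no measured step touches this position; the one step recorded is unreadable, so nothing argues for a change beyond the scatter in this assay in either direction.

For compound 3 the expected value is 320000 nM, with the range 100000 nM to 1000000 nM, most likely again reported only as a limit. The estimated step is therefore a number no higher from compound 1 to compound 3 (the limit leaves the size open).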

Compound 3, half-maximal inhibitory concentration: > 100000 nM
Compound 3: no number, only a limit; the forecaster's own chance of this, stated with the estimate: 85%; the middle value is on the limit's open side.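

In this assay compound 3 gives > 100000 nM, a limit of the assay. Compound 1 is also recorded only as a limit, so the step between compound 1 and compound 3 cannot be read. The compounds shown leave open whether hydroxymethyl in place of hydrogen changes cytotoxicity at all, and none of them carries a numbered value.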